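The source may report more compounds than this note shows. Statements on the series, on what has been measured and on what is new or still open speak of the compounds shown alone.

Working notes on the series built on the core of compound 1 `CCCC(C)Oc1cccc2ccc(N)nc12`, which in an assay on cells with melanin-concentrating hormone receptor 1 (Homo sapiens) as the target, read by radioligand binding (on this read-out higher numbers stand for weaker inhibition and lower numbers for stronger inhibition), gives 105 nM. Compound 2 `Nc1ccc2cccc(OCC3CCCO3)c2n1` reaches only the assay limit, > 2000 nM. Compound 3 `CC#CCCOc1cccc2ccc(N)nc12` likewise sits at the limit, > 2000 nM. The steps of an at least 19-fold higher number from compound 1 to compound 2 (1.27 log units; beyond the scatter) and an at least 19-fold higher number from compound 1 to compound 3 (1.27 log units; beyond the scatter) are both large, while the step that the two limits leave unreadable from compound 2 to compound 3 cannot be read because of the limit of > 2000 nM in this assay, at which 2 of the 3 values shown sit.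

Compound 4 `CCCCOc1cccc2ccc(N)nc12` differs from compound 3 by ethyl in place of prop-1-yn-1-yl on a saturated chain carbon, two bonds along the chain from an oxygen on an aromatic ring. Of the measured steps, an at least 19-fold higher number from compound 1 to compound 3 (1.27 log units; beyond the scatter) bears on it most directly, as the reverse move from a saturated chain to the alkyne cost that much. A step of an at least 6.6-fold lower number from compound 3 to compound 4 (0.82 log units; beyond the scatter) toward stronger inhibition is therefore expected, its size uncertain given the limit at compound 3. For compound 4 the estimate in this assay is 300 nM, with a range of 80 nM to 2000 nM.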

Compound 4, half-maximal inhibitory concentration: 789 nM
Compound 4: the middle estimate sits 2.6-fold (0.42 log units) below what was measured; the measured number falls inside the stated range.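

Butyl in place of pent-3-yn-1-yl gives an at least 2.5-fold lower number from compound 3 to compound 4 (0.40 log units; beyond the scatter), and propyl in place of oxolan-2-yl on the saturated chain carbon gives an at least 2.5-fold lower number from compound 2 to compound 4 (0.40 log units; beyond the scatter). Both steps are lower bounds only: the limit of > 2000 nM in this assay, at which 2 of the 4 values shown sit.

Hydrogen in place of methyl on the saturated chain carbon bound to the oxygen gives a 7.5-fold higher number from compound 1 to compound 4 (0.88 log units; beyond the scatter), so that methyl alone separates compound 1 from compound 4 by a step beyond the scatter.

From the compounds shown here alone, the true size of the two bounded steps stays open. So does the effect of a longer chain, or of an amine at the chain end.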